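This account rests on a few compounds, and the source may have more. Where it says the series, first, only, none or still open, it means among the compounds named here.

Working notes on the series.

Two compounds of the shared core have numbers in a functional assay on NCI-H460 cells (Homo sapiens) for antiproliferative activity; a lower number here means a stronger inhibitor, a higher number a weaker inhibitor. Compound 1 `O=C1N/C(=N\c2ccc(Cl)cc2)S/C1=C/c1ccccc1O` gives 1180 nM in this assay. Compound 2 `COc1ccc(N=C2NC(=O)/C(=C\c3ccc(N(C)C)cc3)S2)cc1` gives 1600 nM in this assay. Of the two numbers, compound 2 has the higher one; compound 1 is its nearest neighbour, and the gap between compound 2 and compound 1 lies within the usual scatter, so the two are not told apart on what is measured.

Compound 3 `CN(C)c1ccc(/C=C2/SC(=Nc3ccccc3Cl)NC2=O)cc1` has not yet been measured in this assay. It differs from compound 2 in one place: 2-chlorophenyl in place of 4-methoxyphenyl on a double-bonded nitrogen. Within the data shown here, no pair of measured compounds differs in one place, so nothing in the measured numbers says how large a change at this place is, or which way it runs; compound 1 carries a different group both here and elsewhere, and its number is within the scatter of compound 2.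

The step from compound 2 to compound 3 is therefore expected to stay within the scatter, a 1.1-fold lower number from compound 2 to compound 3 (0.03 log units; within the scatter), with no direction preferred. For compound 3 the estimate in this assay is 1500 nM, in a range from 500 nM to 4500 nM.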

Compound 3, half-maximal inhibitory concentration: 880 nM
Compound 3: the middle estimate sits 1.7-fold (0.23 log units) above what was measured; low and high end bracket the measured number.
By their numbers in this assay, from the lowest: compounds 3, 1 and 2 (each within the scatter of the next).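

In this assay, among these compounds, the exchange of 4-methoxyphenyl for 2-chlorophenyl on a double-bonded nitrogen gives the first single-place step, a 1.8-fold lower number from compound 2 to compound 3 (0.26 log units; within the scatter), so this place now has a measured step where the earlier compounds offered none. In this pair, a group with 1 hydrogen-bond acceptor and a group with 0 hydrogen-bond acceptors are not told apart, and neither are an oxygen-bearing and a chlorine-bearing phenyl, with everything else in the two molecules the same. Nothing at hand bears on what lies behind this step.

Among the compounds shown here, this single pair covers only two substituted phenyl groups at this place, so it remains open whether the insensitivity extends to other groups there, such as a cyclohexyl ring, which has no aromatic ring, or a phenyl carrying a carboxylic acid or an amine. For the compounds shown here, compound 1 differs from both compound 2 and compound 3 in more than one place, so it adds no further step, and how the group at this place behaves with a different remainder of the molecule also stays open.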